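Working notes: compound 3 as the next step from compound 2

The source may hold more compounds than are shown below. What is called first, only, known or untested is meant among the compounds shown, and "the series" means these compounds.

Measured so far:
compound 1 `CN1CCN(CCCCCn2c3c(c4ccccc42)C(=O)c2c[n+]([O-])c4ccccc4c2C3=O)CC1` — 1710 nM
compound 2 `O=C1c2c[n+]([O-])c3ccccc3c2C(=O)c2c1c1ccccc1n2Cc1cn([C@H]2C[C@H](O)[C@@H](CO)O2)nn1` — 390 nM

For the measured compounds named here, in a functional assay on A-375 cells (Homo sapiens) for cytotoxicity, read by MTT assay, with a stated time of 72 h (a higher number here means a weaker inhibitor, a lower number a stronger inhibitor), compound 2 gives 390 nM and holds the lowest of the two numbers so far. Compound 1 gives 1710 nM in this assay, and the gap between the two lies beyond the usual scatter. Going by the values given here, no step between measured compounds that differ in one place is available, so the two values only show that the group carried on the shared core can shift the number by more than the scatter.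

Compound 3 `CC1(C)OC[C@H](Cn2cc(Cn3c4c(c5ccccc53)C(=O)c3c[n+]([O-])c5ccccc5c3C4=O)nn2)O1` is not yet measured. It differs from compound 2 by (2,2-dimethyl-1,3-dioxolan-4-yl)methyl in place of 4-hydroxy-5-(hydroxymethyl)oxolan-2-yl on an aromatic nitrogen. The change removes both hydrogen-bond donors of the leaving group and adds one hetero atom to the five-membered non-aromatic ring, while keeping the heavy-atom count unchanged.

Among the compounds with values here, with no measured step at this position, the expectation rests only on the spread between compound 1 and compound 2: a moderate move is expected, most likely towards a higher number, but a result within the scatter of compound 2 cannot be excluded. Compound 3 is estimated at 700 nM, with a range from 250 nM to 2000 nM. This estimate means a step of a 1.8-fold higher number from compound 2 to compound 3 (0.25 log units; within the scatter), expected to be modest.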

Compound 3, half-maximal inhibitory concentration: 180 nM
Compound 3: the middle estimate sits 3.9-fold (0.59 log units) above what was measured; measured number outside the range, below it.
By their numbers in this assay, from the lowest: compound 3; then compound 2; then compound 1.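

In this assay, the position on an aromatic nitrogen of the five-membered aromatic ring with 3 nitrogen now has its first readable step: (2,2-dimethyl-1,3-dioxolan-4-yl)methyl in place of 4-hydroxy-5-(hydroxymethyl)oxolan-2-yl gives a 2.2-fold lower number from compound 2 to compound 3 (0.34 log units; beyond the scatter) and so moves the number beyond the scatter with the heavy-atom count unchanged. For this pair, the 2 hydrogen-bond donors of the leaving group are not required for a low number, since the entering group has 0 hydrogen-bond donors and compound 3 gives the lower value. No measurement here accounts for the step.

The change alters the hydrogen-bond donors, the hydrogen-bond acceptors, the hetero atoms in the ring and the defined stereocentres together, so this single step cannot assign the shift to any one of them. A 2,3-dihydroxypropyl group at the same nitrogen would separate the free hydroxyl groups from the ring of the entering group, while the compounds shown also leave open how a simple n-butyl chain or a carboxylic acid would read there.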